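From Methoxy to Nitro on an Aromatic Ring

The source may hold more compounds than are shown below. What is called first, only, known or untested is meant among the compounds shown, and "the series" means these compounds.

Of the compounds shown here, three have been measured in a functional assay on HL-60 cells (Homo sapiens) for inhibition, read by CCK-8 assay, with a stated time of 48 h; a lower number here means a stronger inhibitor, a higher number a weaker inhibitor. Compound 1 (`COc1cccc(NC(=O)NCCNS(=O)(=O)c2ccc(-c3ccccc3OCc3ccccc3)s2)c1`) gives 1700 nM, and compound 2 (`O=S(=O)(NCCNC(=S)Nc1cc(C(F)(F)F)cc(C(F)(F)F)c1)c1ccc(-c2ccccc2OCc2ccccc2)s1`) gives 2100 nM. Compound 3 (`COc1ccc(NC(=S)NCCNS(=O)(=O)c2sccc2-c2ccc(C)cc2Oc2ccc(O)c(O)c2)cc1`) gives 4100 nM. This places compound 3 level with compound 2 within the usual scatter, while it is a weaker inhibitor than compound 1 by a gap beyond the scatter.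

The next compound to be tested is compound 4 (`Cc1ccc(-c2ccsc2S(=O)(=O)NCCNC(=S)Nc2ccc([N+](=O)[O-])cc2)c(Oc2ccc(O)c(O)c2)c1`). It keeps the structure of compound 3 except for one group: nitro in place of methoxy on an aromatic carbon, para to a large group. This turns 4-methoxyphenyl into 4-nitrophenyl (nitro in place of methoxy on an aromatic carbon).

Among the compounds with values here, no two measured compounds differ in only one place, so no measured step shows what this swap does in this assay. Within the data shown here, the only guide is the narrow spread of the measured numbers, with compound 1 at 1700 nM and compound 3 at 4100 nM. A modest shift towards a stronger inhibitor is therefore expected, but none beyond the scatter. The expected step is a 1.2-fold lower number from compound 3 to compound 4 (0.07 log units; within the scatter). For compound 4, the estimated half-maximal inhibitory concentration is 3500 nM, within a range of 1500 nM to 8000 nM.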

Compound 4, half-maximal inhibitory concentration: 2900 nM
Beside the measured number, compound 4's estimate is 1.2-fold (0.08 log units) above it, within the range that was stated.
By their numbers in this assay, from the lowest: compounds 1, 2, 4 and 3 (each within the scatter of the next, the first and the last beyond it).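

Within the data shown here, this is the first pair of compounds that differ in only one place, so it gives the first direct reading of a single swap in this assay. Putting nitro in place of methoxy on an aromatic carbon, para to a large group, gives a 1.4-fold lower number from compound 3 to compound 4 (0.15 log units; within the scatter) and thus leaves the two compounds level. Methoxy, with 2 heavy atoms, and nitro, with 3 heavy atoms and a double bond outside the aromatic rings, are clearly different groups, yet this exchange at this position produces no step that can be told apart from repeat-measurement noise, and no measurement at hand offers a reason for that.

Still open, on these data alone, is whether any other group at this position would move the number beyond the scatter, and an amine, a carboxylic acid or a nitrile in the same place would test that. Also open, as far as these compounds go, is whether the same swap would give a similar step on the core of compound 1, which carries a methoxy group of its own.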